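Swapping one ring stereocentre in a trimethoxyphenyl cyclopropane

This account rests on a few compounds, and the source may have more. Where it says the series, first, only, none or still open, it means among the compounds named here.

Compound 1 `CCOC(=O)[C@@]1(C(=O)Nc2ccccc2Cl)C[C@H]1c1cc(OC)c(OC)c(OC)c1` was tested in a functional assay on K562 cells (Homo sapiens) for cytotoxicity, read by MTT assay, with a stated time of 48 h; on this read-out higher numbers stand for weaker inhibition and lower numbers for stronger inhibition. Compound 1 reaches only the limit of the assay, > 100000 nM, so no number is known for it. Compound 2 `COc1cc([C@H]2C[C@@]2(CO)C(=O)Nc2ccccc2)cc(OC)c1OC` likewise shows only a limit, > 100000 nM. Compound 3 `CCOC(=O)C1(C(=O)NCc2ccc(C)cc2)CC1c1cc(OC)c(OC)c(OC)c1` also returns a limit, > 100000 nM; > 100000 nM (2 entries). Nothing here separates these three; they share (the limit of > 100000 nM in this assay, at which 2 of the 3 values shown sit). Compound 4 `CCOC(=O)[C@]1(C(=O)Nc2ccccc2Cl)C[C@H]1c1cc(OC)c(OC)c(OC)c1` has not yet been measured. Compound 4 differs from compound 1 only as follows: the two compounds have the same atoms and bonds and differ only in configuration as drawn: 1 of 2 stereo elements differ; a stereocentre at a saturated ring carbon is drawn S in compound 1 and R in compound 4. Among the compounds with values here, with no step between two measured compounds available, the expected change is none beyond the scatter, and compound 4 is expected to sit at the same limit. The estimated step that the limit leaves unreadable from compound 1 to compound 4 is therefore small. For compound 4 the estimate is 150000 nM, within 50000 nM to 500000 nM.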

Compound 4, half-maximal inhibitory concentration: 20700 nM
For compound 4 the middle estimate is 7.2-fold (0.86 log units) above the measured one, and the stated range ends above it.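

In this assay, within the data shown here, the earlier compounds gave no readable difference, but changing a single ring stereocentre from S to R gives an at least 4.8-fold lower number from compound 1 to compound 4 (0.68 log units; beyond the scatter). For compound 1 the printed > 100000 nM is a limit of the assay and not a number. The step can be assigned to the configuration at that ring carbon alone, because nothing else changes: the fact that compounds 1 and 4 differ only in the configuration as drawn.

The compounds shown leave open whether the second stereocentre matters too. They also leave open whether compound 4 would keep this activity with a carboxylic acid in place of its ethyl ester.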